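The compounds below may be only part of what the source reports. "The series", "measured", "known", "first", "only" and "open" are said of these compounds alone.

Compounds measured so far:
compound 1 `OCC#Cc1ccccc1C#Cc1ccccc1` with 16600 nM
compound 2 `OCCC#Cc1ccccc1C#Cc1ccccc1` with 17300 nM

In a functional assay on SK-OV-3 cells (Homo sapiens) for cytotoxicity (a higher number here means a weaker inhibitor of growth, a lower number a stronger inhibitor of growth), compound 2 holds the higher of the two numbers, but compound 1 lies within the scatter of it, so the two are indistinguishable. Compound 3 `OCCCCC#Cc1ccccc1C#Cc1ccccc1` carries the change 2-hydroxyethyl in place of hydroxy on a saturated chain carbon, two bonds along the chain from a triple-bonded carbon on the shared core. Among the compounds with values here, the only measured step that bears on it is a 1.0-fold higher number from compound 1 to compound 2 (0.02 log units; within the scatter), which lengthened the same chain and stayed within the scatter. A further lengthening is therefore expected to give no step beyond the scatter, a 1.0-fold lower number from compound 2 to compound 3 (0.01 log units; within the scatter). Compound 3 is estimated at 17000 nM, ranging from 8000 nM to 36000 nM.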

Compound 3, concentration for 50% growth inhibition: 10700 nM
Compound 3: the middle estimate sits 1.6-fold (0.20 log units) above what was measured; low and high end bracket the measured number.
By their numbers in this assay, from the lowest: compounds 3, 1 and 2 (each within the scatter of the next).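

In this assay, 2-hydroxyethyl in place of hydroxy gives a 1.6-fold lower number from compound 2 to compound 3 (0.21 log units; within the scatter) and 3-hydroxypropyl in place of hydroxy gives a 1.6-fold lower number from compound 1 to compound 3 (0.19 log units; within the scatter) and neither step can be told apart from ordinary repeat variation. The earlier pair covered only one added chain unit, whereas these steps show that the wider span of chain lengths, each still ending in hydroxy, also leaves the three compounds indistinguishable. Going by these compounds, whether a longer chain, or an amine or carboxylic acid in place of the hydroxy, would give a step beyond the scatter stays open. No supporting measurement is available to explain these numbers.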